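Hydrazone substituent swap on the shared nucleoside core

This account rests on a few compounds, and the source may have more. Where it says the series, first, only, none or still open, it means among the compounds named here.

Compound 1 `COc1ccc(/C=N/Nc2nc(N)c3ncn([C@@H]4O[C@H](CO)[C@@H](O)[C@H]4O)c3n2)cn1` — in an assay on CHO-K1 cells for displacement of a labelled ligand from adenosine receptor A1 (Homo sapiens), read by scintillation counting, with a stated time of 60 min (on this read-out higher numbers stand for weaker inhibition and lower numbers for stronger inhibition), compound 1 gives 2.6 nM.
Compound 2 `Nc1nc(N/N=C/c2ccc(Cl)c(C(F)(F)F)c2)nc2c1ncn2[C@@H]1O[C@H](CO)[C@@H](O)[C@H]1O` — in this assay compound 2 reaches only the limit > 10000 nM.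

Compound 2 sits at the limit (the limit of > 10000 nM in this assay, at which 1 of the 2 values shown sits), so only a bound is known for it. Compound 3 `Nc1nc(N/N=C/C2CCCC2)nc2c1ncn2[C@@H]1O[C@H](CO)[C@@H](O)[C@H]1O` carries cyclopentyl in place of 4-chloro-3-(trifluoromethyl)phenyl on a carbon with a double bond to nitrogen. Within the data shown here, the one measured step that bears on this position, an at least 3800-fold higher number from compound 1 to compound 2 (3.58 log units; beyond the scatter), shows that exchanging the group on this carbon can move this assay strongly; its direction for a cyclopentyl is not settled by anything measured. Compound 3 is therefore expected to regain some binding, estimated at 1500 nM (range 50 nM to 20000 nM), a step of an at least 6.6-fold lower number from compound 2 to compound 3 (0.82 log units; beyond the scatter).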

Compound 3, inhibition constant: 5.6 nM
Beside the measured number, compound 3's estimate is 270-fold (2.43 log units) above it, outside the stated range (below it).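

In this assay, cyclopentyl on this carbon gives an at least 1700-fold lower number from compound 2 to compound 3 (3.25 log units; beyond the scatter), so the loss seen with 4-chloro-3-(trifluoromethyl)phenyl does not extend to every replacement of 6-methoxypyridin-3-yl. The change to a non-aromatic ring gives only a 2.2-fold higher number from compound 1 to compound 3 (0.33 log units; beyond the scatter), so an aromatic ring is not needed here for a low number. Compound 2 stands at a limit of the assay, not at a number: the limit of > 10000 nM in this assay, at which 1 of the 3 values shown sits.

Which part of 4-chloro-3-(trifluoromethyl)phenyl accounts for the loss remains open. Also open, on these data alone, is how an unsubstituted phenyl, a cyclohexyl or an open butyl chain would behave on this carbon.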